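A few compounds are considered here, and "the series" means these few. Any claim that something is new, unique, unknown or untested is made for them only; others in the source may bear on it.

Working notes on the series around the core of compound 1 `O=C(COc1ccccc1)Nc1cccc(C(=O)O)c1`. In a functional assay on AGS cells (Homo sapiens) for inhibition, read by reporter gene assay (a lower number here means a stronger inhibitor, a higher number a weaker inhibitor), compound 1 gives > 30000 nM, which is a limit of the assay and not a number. Compound 2 `CC(C)(C)c1ccc(OCC(=O)Nc2cccc(C(=O)O)c2)cc1` gives 9500 nM in this assay. Compound 3 `O=C(COc1ccc(F)cc1)Nc1cccc(C(=O)O)c1` gives > 30000 nM in this assay, again a limit of the assay rather than a number. Compound 3 therefore stands at the limit of > 30000 nM in this assay, at which 2 of the 3 values shown sit, and only compound 2 lies below it with a read number. The measured steps are an at least 3.1-fold lower number from compound 1 to compound 2 (0.49 log units; beyond the scatter) and an at least 3.1-fold higher number from compound 2 to compound 3 (0.49 log units; beyond the scatter), both beyond the scatter, while a step that the two limits leave unreadable from compound 1 to compound 3 cannot be read against the two limits. Compound 4 `O=C(COc1ccc(Br)cc1)Nc1cccc(C(=O)O)c1` is the next member; it differs from compound 3 by bromo in place of fluoro on an aromatic carbon. The steps bearing on it concern tert-butyl against hydrogen and against fluoro, not bromo, so they set only a loose frame. A bromo group is expected to move the number modestly downward from the limit, as an estimate of an at least 1.6-fold lower number from compound 3 to compound 4 (0.22 log units; that floor lies within the scatter) in this assay. For compound 4 the expected value is 18000 nM, within an estimated range of 7000 nM to 45000 nM.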

Compound 4, half-maximal inhibitory concentration: 1600 nM
The estimate for compound 4 lay 11-fold (1.05 log units) above the measured number; measured number outside the range, below it.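

In this assay, the place para to a large group separates two halogens sharply: bromo in place of fluoro gives an at least 18-fold lower number from compound 3 to compound 4 (1.27 log units; beyond the scatter), so the 4-fluorophenyl and 4-bromophenyl members cannot be treated as equivalent. Bromo also improves on tert-butyl, with a 5.9-fold lower number from compound 2 to compound 4 (0.77 log units; beyond the scatter), which makes compound 4 the strongest of the four and shows that tert-butyl is not the best group shown at this place. Against hydrogen the change gives an at least 18-fold lower number from compound 1 to compound 4 (1.27 log units; beyond the scatter), and this step and the one from fluoro are floors rather than full sizes, since each starts from a limit of the assay: the limit of > 30000 nM in this assay, at which 2 of the 4 values shown sit.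

The compounds shown leave open whether chloro or iodo at this place would read closer to fluoro or to bromo. Also open, as far as these compounds go, is how a methoxy group, an amine or a longer chain would read there.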